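One More Carbon Between the Chain and the Phenyl Ring

The compounds below may be only part of what the source reports. "The series", "measured", "known", "first", "only" and "open" are said of these compounds alone.

Three related amides were tested in a functional assay on PC-3 cells (Homo sapiens) for cytotoxicity, read by sulforhodamine B assay, with a stated time of 5 days; a lower number here means a stronger inhibitor, a higher number a weaker inhibitor. Compound 1 `O=C(CCCCCc1ccccc1)N[C@H]1CCOC1=O` gives > 100000 nM in this assay, which is a limit rather than a number, so compound 1 stands at the weak end of everything shown, as the limit of > 100000 nM in this assay, at which 2 of the 3 values shown sit, describes. Compound 2 `O=C(CCCCCCCCc1ccccc1)N[C@H]1CCOC1=O` gives 67000 nM in this assay, a number rather than a limit. Compound 3 `O=C(CCCc1ccccc1)CC(=O)N[C@H]1CCOC1=O` gives > 100000 nM in this assay, again a limit. Compound 4 `O=C(CCCCCCc1ccccc1)N[C@H]1CCOC1=O` has not yet been measured; it differs from compound 1 by benzyl in place of phenyl on a saturated chain carbon, five bonds along the chain from a carbonyl carbon. Within the data shown here, no pair differing in one place has been measured, so no step size can be read from the data. The step of a number no higher from compound 1 to compound 4 (the limit leaves the size open) is expected to be none beyond the scatter. The estimate for compound 4 is 100000 nM, within 50000 nM to 200000 nM, quite possibly again a limit.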

Compound 4, half-maximal inhibitory concentration: > 100000 nM
Compound 4 was reported as a limit (the forecaster's own chance of this, stated with the estimate: 55%); the middle value sits exactly at the limit.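

Compound 1 and compound 4 are both reported only as limits in this assay, so no step between them can be read: the limit of > 100000 nM in this assay, at which 3 of the 4 values shown sit.

As far as these compounds go, whether benzyl in place of phenyl changes potency at all remains open.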